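Ring amine methylation across two bridged cores

The compounds below may be only part of what the source reports. "The series", "measured", "known", "first", "only" and "open" are said of these compounds alone.

Compound 2 `C1=C(c2cccnc2)C[C@H]2CNC[C@@H]1C2` gives 0.95 nM in a functional assay on synaptosomes from brain (strain Sprague-Dawley) for agonist activity at Nicotinic acetylcholine receptor alpha6/alpha3/beta2/beta3 (Rattus norvegicus); a higher number here means that more compound is needed for the effect, a lower number that less compound is needed. Compound 1 `CN1C[C@H]2C=C(c3cccnc3)C[C@H](C2)C1` gives > 10000 nM in this assay, which is a limit of the assay and not a number. The step of an at least 10000-fold higher number from compound 2 to compound 1 (4.02 log units; beyond the scatter) follows from the change methyl in place of hydrogen on an amine nitrogen in a ring and its true size cannot be fixed more closely because of the limit of > 10000 nM in this assay, at which 1 of the 3 values shown sits.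

Compound 3 `CC(C)Oc1cncc(C2=CC3CNCC(C2)C3)c1` gives 1090 nM in this assay. The difference between the core of compound 3 and the core of compound 2 is not broken down here.

Compound 4 `CC(C)Oc1cncc(C2=CC3CC(C2)CN(C)C3)c1` carries the same change, (methyl in place of hydrogen on an amine nitrogen in a ring), and awaits measurement in this assay. Among the measured compounds shown here, the only precedent, an at least 10000-fold higher number from compound 2 to compound 1 (4.02 log units; beyond the scatter), was large. For compound 4 the step is expected to be a 46-fold higher number from compound 3 to compound 4 (1.66 log units; beyond the scatter), resting on that precedent and on compound 3 giving 1090 nM. Compound 4 is therefore expected to give 50000 nM, plausibly reported only as a limit.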

Compound 4, half-maximal effective concentration: 879 nM
Compound 4: the middle estimate sits 57-fold (1.75 log units) above what was measured; measured number below the stated range.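

Methyl in place of hydrogen on an amine nitrogen in a ring does not give the same outcome on both cores in this assay: the same change on two cores in this assay, an at least 10000-fold higher number (4.02 log units; beyond the scatter) from compound 2 to compound 1 and a 1.2-fold lower number (0.09 log units; within the scatter) from compound 3 to compound 4, at least 13000-fold (4.11 log units) apart, beyond the scatter of two such steps. The new step, a 1.2-fold lower number from compound 3 to compound 4 (0.09 log units; within the scatter), shows no change beyond the scatter on this core, but the two steps alone do not show which feature of the cores separates them. Compound 1 gives > 10000 nM, which is a limit of the assay and not a number, so the earlier step has no fixed size.

Which part of the difference between the two cores decides the outcome remains open. Also open, going by these compounds, is whether an ethyl group or a longer chain on the same amine nitrogen would follow compound 1 or compound 4.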